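Ring size and amide substitution on a carbonyl-linked side chain

The source may report more compounds than this note shows. Statements on the series, on what has been measured and on what is new or still open speak of the compounds shown alone.

Measured so far:
Compound 1, `CC(=O)N1CCCC(NC(=O)c2ccncc2Nc2cc(-c3ccc4ccn(C)c4c3)c3nccnc3c2)C1`, in an assay on lysate for inhibition of 6-phosphofructo-2-kinase/fructose-2,6-bisphosphatase 3 (Homo sapiens), with stated times of 0.5 min and 45 min (a lower number here means a stronger inhibitor, a higher number a weaker inhibitor), gives 13500 nM.
Compound 2, `CC(=O)N1CC(NC(=O)c2ccncc2Nc2cc(-c3ccc4ccn(C)c4c3)c3nccnc3c2)C1`, in this assay gives 97400 nM.

Compound 2 is the weaker of the two measured compounds: the step of a 7.2-fold higher number from compound 1 to compound 2 (0.86 log units; beyond the scatter) puts it beyond the scatter from compound 1. Compound 3, `CN1CCC(N(C)C(=O)c2ccncc2Nc2cc(-c3ccc4ccn(C)c4c3)c3nccnc3c2)C1`, differs from compound 2 by methyl(1-methylpyrrolidin-3-yl)amino in place of (1-acetylazetidin-3-yl)amino on a carbonyl carbon. For the measured compounds named here, the only measured step, a 7.2-fold higher number from compound 1 to compound 2 (0.86 log units; beyond the scatter), concerns a change of ring size on the same side chain and says nothing about replacing the acetyl group with a methyl group or removing the amide hydrogen. Since compound 3 carries a five-membered ring, between the four-membered ring of compound 2 and the six-membered ring of compound 1, a modest recovery toward compound 1 is expected, with wide uncertainty. Compound 3 is therefore expected at 30000 nM, between 8000 nM and 120000 nM, the estimated step being a 3.2-fold lower number from compound 2 to compound 3 (0.51 log units; beyond the scatter).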

Compound 3, half-maximal inhibitory concentration: 39700 nM
Beside the measured number, compound 3's estimate is 1.3-fold (0.12 log units) below it; low and high end bracket the measured number.
By their numbers in this assay, from the lowest: compound 1; then compound 3; then compound 2.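

At this carbonyl carbon, the side chain need not keep the acetyl group or the amide hydrogen to improve on compound 2: methyl(1-methylpyrrolidin-3-yl)amino gives a 2.5-fold lower number from compound 2 to compound 3 (0.39 log units; beyond the scatter) in this assay. It does not match the six-membered ring of the acetylated side chain, however, with a 2.9-fold higher number from compound 1 to compound 3 (0.47 log units; beyond the scatter). Ring size, the acetyl group and the amide hydrogen all change at once in these steps, so neither step can be assigned to any one of them, and no evidence on the cause bears on this result.

The compounds shown leave open what each change contributes alone, for example how (1-acetylpyrrolidin-3-yl)amino would compare. They also leave open whether a primary amine on the ring or an open-chain dimethylaminoethyl group would serve at this carbonyl carbon.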